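A few compounds are considered here, and "the series" means these few. Any claim that something is new, unique, unknown or untested is made for them only; others in the source may bear on it.

Measured in an ADME assay on the whole organism (Mus musculus, strain CD1) for pharmacokinetics, at a dose of 2 mg/kg by the intravenous route; a higher number here means faster removal of the compound, a lower number slower removal:
- Compound 1 `CN1CCC(Oc2ccc(N3C(=S)N(c4cnc(C#N)c(C(F)(F)F)c4)C(=O)C34CCC4)cn2)CC1`: 8.14 mL/min/kg
- Compound 2 `Cc1cc(N2C(=O)C3(CCC3)N(c3ccc(OC4CCNCC4)nc3)C2=S)cnc1C#N`: 19.4 mL/min/kg
- Compound 3 `COc1cc(N2C(=O)C3(CCC3)N(c3ccc(OC4CCN(C)CC4)cc3)C2=S)cnc1C#N`: 6.9 mL/min/kg

Among these three, compound 2 stands highest in this assay at 19.4 mL/min/kg, and its gaps to the other two lie beyond the scatter. Compound 1 comes nearest to it, and compound 3 lies furthest away.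

The next compound to be tested is compound 4 `N#Cc1ncc(N2C(=O)C3(CCC3)N(c3ccc(OC4CCNCC4)nc3)C2=S)cc1C(F)(F)F`. It departs from compound 2 in one place, with trifluoromethyl in place of methyl on an aromatic carbon, ortho to a cyano group: trifluoromethyl in place of methyl on an aromatic carbon.

Among the measured compounds shown here, no pair of measured compounds isolates this change, so any forecast rests on thin evidence. The closest guide is compound 1, which carries the same trifluoromethyl group and gives 8.14 mL/min/kg. However, compound 1 also differs from compound 4 elsewhere, so its value can only hint at a direction.

The expected step is a small fall that stays within the scatter: a 1.4-fold lower number from compound 2 to compound 4 (0.14 log units; within the scatter). A wide range is warranted, since a single indirect comparison supports this expectation. For compound 4 the estimated value is 14 mL/min/kg, with an expected range from 7 mL/min/kg to 28 mL/min/kg.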

Compound 4, clearance: 15 mL/min/kg
Compound 4: middle estimate off by 1.1-fold (0.03 log units), on the low side; the measured number falls inside the stated range.
By their numbers in this assay, from the lowest: compounds 3, 1, 4 and 2 (each within the scatter of the next, the first and the last beyond it).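

In this assay, among the compounds shown here, trifluoromethyl in place of methyl on the aromatic carbon ortho to a cyano group gives a 1.3-fold lower number from compound 2 to compound 4 (0.11 log units; within the scatter), a direct reading of this change at this position that the earlier compounds could not offer, and it shows that the change does not separate the two compounds beyond the scatter. With the trifluoromethyl group held constant, hydrogen in place of methyl on the amine nitrogen in the ring gives a 1.8-fold higher number from compound 1 to compound 4 (0.27 log units; within the scatter), so this second single change also stays within the scatter. No measurement at hand accounts for either step.

From the compounds shown here alone, each change is read from one pair only, so it remains open whether either step would stay this small on a different background. Also open, going by these compounds, is how this assay would respond to a chlorine atom or an ethyl group at this aromatic position, or to an acetyl or ethyl group on the ring amine nitrogen.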